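Swapping Bromophenyl for Methylphenyl on the Amide Nitrogen

This account rests on a few compounds, and the source may have more. Where it says the series, first, only, none or still open, it means among the compounds named here.

In a functional assay on the whole organism (strain Swiss Albino) for inhibition, with Mus musculus as the target, in the writhing test, with a stated time of 1 h, at a dose of 100 mg/kg by the oral route (on this read-out higher numbers stand for more inhibition at the one dose given (going by the name of the read-out) and lower numbers for less inhibition), the two measured compounds are: compound 1 `COc1cc2c(cc1OC)C(CC(=O)Nc1ccc(Cl)cc1)CC2` with 73.6%; compound 2 `COc1cc2c(cc1OC)C(CC(=O)Nc1ccc(Br)cc1)CC2` with 37.5%.

Compound 2 stands lowest of the two numbers; the only step shown, a number 36.1 percentage points lower from compound 1 to compound 2 (beyond the scatter), is large. Compound 3 `COc1cc2c(cc1OC)C(CC(=O)Nc1cccc(C)c1)CC2` changes compound 2 by 3-methylphenyl in place of 4-bromophenyl on an amide-type nitrogen. For the measured compounds named here, no measured step trades a bromophenyl for a methylphenyl, so the chloro-to-bromo step bears on it only as a sign that this group moves the read-out strongly; the direction remains open. Compound 3 is therefore estimated at 50%, within 25% to 75%. This estimate means an expected step of a number 12.5 percentage points higher from compound 2 to compound 3 (beyond the scatter), held with wide uncertainty.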

Compound 3, a percentage reported as inhibition, in the whole organism at one dose (the size of the read-out at that dose, not a potency): 54.3%
For compound 3 the middle estimate is 4.3 percentage points below the measured one; low and high end bracket the measured number.
By their numbers in this assay, from the lowest: compound 2; then compound 3; then compound 1.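

A phenyl ring with no halogen on the amide nitrogen still gives clear inhibition, and 3-methylphenyl has no single direction of effect against the halogen-bearing rings: the result is a number 16.8 percentage points higher from compound 2 to compound 3 (beyond the scatter), yet a number 19.3 percentage points lower from compound 1 to compound 3 (beyond the scatter). Both steps change the group and its place on the ring together, so neither can be credited to the methyl alone. No measurement here accounts for these differences.

Going by these compounds, how 4-methylphenyl would compare stays open, and it would separate those two changes. So does the effect of a methoxy group or an amine on the ring.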